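Sulfonyl aryl swap from compound 2 to compound 3

This account rests on a few compounds, and the source may have more. Where it says the series, first, only, none or still open, it means among the compounds named here.

Measured in a functional assay on MCF7 cells (Homo sapiens) for antiproliferative activity, read by MTT assay, with a stated time of 48 h; on this read-out higher numbers stand for weaker inhibition and lower numbers for stronger inhibition:
- compound 1 `O=C(/C=C/c1cn(S(=O)(=O)c2ccc([N+](=O)[O-])cc2)c2ccccc12)c1ccncc1` gives 14500 nM; "dose-dependent effect" (no number reported) (2 entries)
- compound 2 `Cc1ccc(S(=O)(=O)n2cc(/C=C/C(=O)c3ccncc3)c3ccccc32)cc1` gives 48900 nM

Compound 2 holds the higher of the two values, at 48900 nM. Behind compound 1 stand (the several entries of compound 1 in this assay, 14500 nM; "dose-dependent effect" (no number reported) (2 entries)).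

Compound 3 `O=C(/C=C/c1cn(S(=O)(=O)c2cccc([N+](=O)[O-])c2)c2ccccc12)c1ccncc1` carries 3-nitrophenyl in place of 4-methylphenyl on a sulfonyl sulfur. Among the measured compounds shown here, this change has no measured step in this assay. A moderate move to lower values, beyond the scatter, is expected, resting on compound 1 at 14500 nM; "dose-dependent effect" (no number reported) (2 entries), the closest measured structure. The expected move is a 2.4-fold lower number from compound 2 to compound 3 (0.39 log units; beyond the scatter). For compound 3 the estimate is 20000 nM, with an expected range of 8000 nM to 50000 nM.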

Compound 3, half-maximal inhibitory concentration: 36300 nM
For compound 3 the middle estimate is 1.8-fold (0.26 log units) below the measured one; low and high end bracket the measured number.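

In this assay the swap gives a 1.3-fold lower number from compound 2 to compound 3 (0.13 log units; within the scatter), so on this sulfonyl sulfur 3-nitrophenyl and 4-methylphenyl are not told apart. A nitro group on this aryl ring therefore does not alone go with a lower number, as compound 3 at 36300 nM shows. The lower value in the series stays with compound 1, the nitro isomer of compound 3: the several entries of compound 1 in this assay, 14500 nM; "dose-dependent effect" (no number reported) (2 entries)

From the compounds shown here alone, whether an amine or a carboxylic acid on this aryl ring would read differently stays open. So does whether an unsubstituted phenyl would sit with compound 2 and compound 3.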